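The source may report more compounds than this note shows. Statements on the series, on what has been measured and on what is new or still open speak of the compounds shown alone.

Of the compounds shown here, three sharing one core have been tested in a functional assay on PC-3 cells (Homo sapiens) for cytotoxicity, read by MTT assay, with a stated time of 48 h; a lower number here means a stronger inhibitor, a higher number a weaker inhibitor. Compound 1, `OC[C@@H]1C[C@H](CO)[C@@H]2C(c3ccc(Cl)cc3)=NO[C@H]12`, carries a chloro group on an aromatic carbon. In this assay compound 1 reaches only a limit, > 50 ug/mL. Compound 2, `N#Cc1ccc(C2=NO[C@@H]3[C@H](CO)C[C@H](CO)[C@H]23)cc1`, carries a cyano group in the same position. In this assay compound 2 likewise reaches only a limit, > 50 ug/mL. Compound 3, `COc1ccc(C2=NO[C@@H]3[C@H](CO)C[C@H](CO)[C@H]23)cc1`, carries a methoxy group there. In this assay compound 3 also reaches only a limit, > 50 ug/mL. The steps between these three cannot be sized because the limit of > 50 ug/mL in this assay, at which 3 of the 3 values shown sit, covers every reading: a step that the two limits leave unreadable from compound 1 to compound 2, a step that the two limits leave unreadable from compound 1 to compound 3 and a step that the two limits leave unreadable from compound 2 to compound 3 all stay unreadable. Compound 3 thus stands exactly where the other two stand, at the edge of what the assay reports.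

Compound 4, `OC[C@@H]1C[C@H](CO)[C@@H]2C(c3ccc(F)cc3)=NO[C@H]12`, differs from compound 3 in one place: fluoro in place of methoxy on an aromatic carbon. The three measured steps bear on it only in that each exchanged one small group at the same aromatic carbon, and none of them produced a readable number. Among the compounds with values here, no step is available to size the change. The expected step that the limit leaves unreadable from compound 3 to compound 4 is therefore small, with a limit again the most likely outcome. Compound 4 is expected to give 65 ug/mL, within the range 30 ug/mL to 200 ug/mL.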

Compound 4, half-maximal inhibitory concentration: > 50 ug/mL
Compound 4 ended at the assay's limit (the forecaster's own chance of this, stated with the estimate: 85%); the middle value lies beyond the limit too.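

Within the data shown here, no step from compound 4 to compound 1, compound 2 or compound 3 can be read in this assay, because all four compounds stop at the same limit: the limit of > 50 ug/mL in this assay, at which 4 of the 4 values shown sit. The compounds shown leave open how far apart the chloro, cyano, methoxy and fluoro compounds truly lie, and whether any group at this aromatic carbon gives a measurable reading.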